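The source may hold more compounds than are shown below. What is called first, only, known or untested is meant among the compounds shown, and "the series" means these compounds.

Compound 1 `Cc1ccc2[nH]c(C(=O)N[C@H]3CN(S(=O)(=O)c4ccnnc4)C[C@@H]3C(=O)NCCN(C)C)cc2c1` gives 89%.
Compound 2 `Cc1ccc2[nH]c(C(=O)N[C@H]3CN(S(=O)(=O)c4cnccn4)C[C@@H]3C(=O)NCCN(C)C)cc2c1` gives 92%.
Compound 3 `Cc1ccc2[nH]c(C(=O)N[C@H]3CN(S(=O)(=O)c4ccnc(C)c4)C[C@@H]3C(=O)NCCN(C)C)cc2c1` gives 91%.

All three numbers come from a functional assay on HEK293 cells for agonist activity at growth hormone secretagogue receptor type 1 (Homo sapiens), read by HTRF and inositol phosphate accumulation, with a stated time of 90 min, in the presence of a further agent that is not named here; a lower number here means a smaller maximal response, a higher number a larger maximal response. On the numbers as they stand, compound 2 sits highest of the three, but the gaps are small: the step of a number 3 percentage points higher from compound 1 to compound 2 (within the scatter) and the step of a number 1 percentage points lower from compound 2 to compound 3 (within the scatter) are both within the usual scatter, so the three compounds cannot really be told apart on maximal response.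

The next compound, compound 4 `Cc1ccc2[nH]c(C(=O)N[C@H]3CN(S(=O)(=O)C4CCOCC4)C[C@@H]3C(=O)NCCN(C)C)cc2c1`, differs from compound 2 in one place: oxan-4-yl in place of pyrazin-2-yl on a sulfonyl sulfur.

Which measured steps bear on this? The steps of a number 3 percentage points higher from compound 1 to compound 2 (within the scatter), a number 2 percentage points higher from compound 1 to compound 3 (within the scatter) and a number 1 percentage points lower from compound 2 to compound 3 (within the scatter) all exchange one six-membered aromatic ring for another on the same sulfonyl sulfur, and every one of them stayed within the scatter. Among the compounds with values here, none of them puts a non-aromatic ring in that place, so there is no direct precedent for the oxan-4-yl group. What the three steps do show is that the group on the sulfonyl sulfur, at least among these aromatic rings, has not moved the maximal response beyond the scatter.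

Compound 4 is therefore expected to give about 88%, with a range from 76% to 97%. The expected step is a number 4 percentage points lower from compound 2 to compound 4 (within the scatter), that is, no change beyond the scatter, with the lower end of the range allowing for the lack of any measured non-aromatic example.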

Compound 4, largest response reached (Emax), in percent of the reference or control that the assay uses: 90%
For compound 4 the middle estimate is 2 percentage points below the measured one, within the range that was stated.
By their numbers in this assay, from the lowest: compounds 1, 4, 3 and 2 (each within the scatter of the next).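

Read in this assay the steps are a number 2 percentage points lower from compound 2 to compound 4 (within the scatter) and a number 1 percentage points lower from compound 3 to compound 4 (within the scatter) and a number 1 percentage points higher from compound 1 to compound 4 (within the scatter) when oxan-4-yl takes the place of each aromatic ring on the sulfonyl sulfur. The earlier compounds shown here only traded one six-membered aromatic ring for another, whereas these steps show that the maximal response also stays level when the ring at this place is non-aromatic and its hetero atom is oxygen rather than nitrogen. Nothing among the data shown offers a measured reason for this.

Going by these compounds, all four compounds carry a six-membered ring on the sulfonyl sulfur, so it remains open whether the maximal response would also hold with a simple open chain such as methyl or ethyl there, or with a ring bearing an amine or a carboxylic acid. The read-out gives only the largest response reached, which leaves open how much of each compound is needed to reach it, so compounds that cannot be told apart here could still differ in that respect.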